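A few compounds are considered here, and "the series" means these few. Any claim that something is new, unique, unknown or untested is made for them only; others in the source may bear on it.

In a functional assay on A2780 cells (Homo sapiens) for cytotoxicity, read by sulforhodamine B assay, with a stated time of 72 h (a lower number here means a stronger inhibitor, a higher number a weaker inhibitor), two compounds have been measured:
compound 1 (`O=C(NCc1ccc(S(=O)(=O)C2CCOCC2)cc1)N1Cc2ccncc2C1`): 35 nM
compound 2 (`O=C(NCc1ccc(S(=O)(=O)N2CCC[C@H](O)C2)cc1)N1Cc2ccncc2C1`): 150 nM

Among the measured compounds shown here, compound 2 holds the higher of the two numbers, and the only measured step is a 4.3-fold higher number from compound 1 to compound 2 (0.63 log units; beyond the scatter) in this pair. Compound 3 (`O=C(NCc1ccc(S(=O)(=O)N2CC3(CCOCC3)C2)cc1)N1Cc2ccncc2C1`) differs from compound 2 in one place: a group of 9 heavy atoms (7 carbon, 1 nitrogen, 1 oxygen; one four-membered non-aromatic ring with 1 hetero atom, one six-membered non-aromatic ring with 1 hetero atom) in place of a group of 7 heavy atoms (5 carbon, 1 nitrogen, 1 oxygen; one six-membered non-aromatic ring with 1 hetero atom), on a sulfonyl sulfur while the rest of the molecule stays the same.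

For the measured compounds named here, that single measured step, also made on the sulfonyl sulfur, is modest and gives the only guide. Going by the values given here, no measured compound carries the entering group, so the guide is a rough one. In this assay a modest step toward a lower number is therefore expected, no larger than the measured one. The estimate is a 2.3-fold lower number from compound 2 to compound 3 (0.36 log units; beyond the scatter) as the expected change. For compound 3 the expected value is 65 nM with an estimated range from 20 nM to 200 nM in all.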

Compound 3, half-maximal inhibitory concentration: 10 nM
For compound 3 the middle estimate is 6.5-fold (0.81 log units) above the measured one; measured number below the stated range.
By their numbers in this assay, from the lowest: compound 3; then compound 1; then compound 2.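

In this assay the sulfonyl sulfur accepts a larger group than either earlier compound carried, and the group with a four-membered and a six-membered non-aromatic ring gives a 15-fold lower number from compound 2 to compound 3 (1.18 log units; beyond the scatter) in a change that also removes the hydrogen-bond donor and the defined stereocentre of 3-hydroxypiperidin-1-yl. The same group also improves on the oxan-4-yl group, with a 3.5-fold lower number from compound 1 to compound 3 (0.54 log units; beyond the scatter) so that compound 3 now holds the lowest number of the three, and both steps lie beyond the scatter. Nothing available bears on the reason for these steps.

The compounds shown leave open how a plain azetidin-1-yl or a morpholin-4-yl group on the sulfonyl sulfur would compare. The share of each ring of the entering group in these steps therefore cannot be told apart.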